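Fluoro for trifluoromethyl on compound 3

The source may hold more compounds than are shown below. What is called first, only, known or untested is meant among the compounds shown, and "the series" means these compounds.

Measured in (an ADME assay on microsomes from liver (Homo sapiens) for metabolic stability, with a stated time of 10 min; a higher number here means that more of the compound is left, a lower number that less of the compound is left):
Compound 1 `FC(F)(F)c1ccccc1-c1ccc2[nH]c(C3=NCC4(CCCCC4)O3)nc2c1` gives 73%
Compound 2 `FC(F)(F)c1ccccc1-c1ccc2[nH]c(C3=NCC4(CCCCC4)N3)nc2c1` gives 97%
Compound 3 `FC(F)(F)c1ccccc1-c1ccc2[nH]c(C3=NOC4(CCCCC4)C3)nc2c1` gives 100%

Compound 3 (100%) lies within the scatter of compound 2 (97%) and stands higher, beyond the scatter, than compound 1 (73%). Compound 4 `Fc1ccccc1-c1ccc2[nH]c(C3=NOC4(CCCCC4)C3)nc2c1` carries fluoro in place of trifluoromethyl on an aromatic carbon, ortho to a large group (fluoro in place of trifluoromethyl on an aromatic carbon). Among the measured compounds shown here, all three measured compounds keep trifluoromethyl, so no measured pair tests this change. In (this assay) a small fall is expected, not clearly beyond the scatter (a number 10 percentage points lower from compound 3 to compound 4 (within the scatter)). For compound 4 the estimated value is (90%), with an expected range from (70%) to (100%).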

Compound 4, percent of the compound remaining: 79%
Estimate against measurement, compound 4: 11 percentage points above; the range from low to high includes it.
By their numbers in this assay, from the lowest: compounds 1 and 4 (each within the scatter of the next); then compounds 2 and 3 (each within the scatter of the next).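

In this assay, the change at this position gives a number 21 percentage points lower from compound 3 to compound 4 (beyond the scatter), a step beyond the scatter. Among the compounds shown here, on this aromatic carbon, ortho to a large group, fluoro therefore does not match trifluoromethyl, which the earlier compounds could not show because all of them keep trifluoromethyl. This rests on a single pair on one core. On these data alone, whether chloro or methoxy at the same place would stand with compound 3 or with compound 4 remains open, as does whether the step would recur on the cores of compound 1 and compound 2. Nothing measured here explains the fall.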